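The compounds below may be only part of what the source reports. "The series", "measured", "known", "first", "only" and "open" are said of these compounds alone.

Working notes on the chromone dithiocarbamate series.

Three compounds have been run in a functional assay on HeLa cells (Homo sapiens) for antiproliferative activity, read by MTT assay, with a stated time of 72 h; a lower number here means a stronger inhibitor, a higher number a weaker inhibitor. Compound 1 `O=c1cc(CSC(=S)N2CCCC2)oc2cc(Cl)ccc12` carries a pyrrolidin-1-yl group on the thiocarbonyl carbon; in this assay compound 1 gives only a limit, > 40000 nM, so no number is available for it (the limit of > 40000 nM in this assay, at which 1 of the 3 values shown sits). Compound 3 `O=c1cc(CSC(=S)N2CCOCC2)oc2cc(Cl)ccc12` shares the core of compound 1 but carries morpholin-4-yl instead; in this assay compound 3 gives 33300 nM. The change between them, (pyrrolidin-1-yl in place of morpholin-4-yl on a thiocarbonyl carbon), gave an at least 1.2-fold higher number from compound 3 to compound 1 (0.07 log units; that floor lies within the scatter), and since one side is a limit, the true size of that step is not fixed. Compound 2 `COc1ccc2occ(CSC(=S)N3CCOCC3)c(=O)c2c1` is built on a different core, with the morpholin-4-yl group retained; in this assay compound 2 gives 9500 nM, which stands as the lowest of the two numbers, with compound 3 as the nearest value. The difference between the core of compound 2 and the core of compound 3 is not broken down here.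

Compound 4 `COc1ccc2occ(CSC(=S)N3CCCC3)c(=O)c2c1` is compound 2 with the same change, (pyrrolidin-1-yl in place of morpholin-4-yl on a thiocarbonyl carbon). The step from compound 2 to compound 4 is expected to run in the same direction as the step from compound 3 to compound 1, that is toward a higher number, and its expected size is a 1.6-fold higher number from compound 2 to compound 4 (0.20 log units; within the scatter), on the grounds that the earlier step had a floor within the scatter and no upper bound. Compound 4 is therefore expected to give about 15000 nM in this assay, with a likely range from 6000 nM to 40000 nM.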

Compound 4, half-maximal inhibitory concentration: 12100 nM
The estimate for compound 4 lay 1.2-fold (0.09 log units) above the measured number; measured number inside the range.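

The new step on the core of compound 2 is small: in this assay, pyrrolidin-1-yl in place of morpholin-4-yl on a thiocarbonyl carbon gives a 1.3-fold higher number from compound 2 to compound 4 (0.11 log units; within the scatter). Set beside the earlier step, the result for carrying this change from one core to the other reads as follows: the same change on two cores in this assay, an at least 1.2-fold higher number (0.07 log units; that floor lies within the scatter) from compound 3 to compound 1 and a 1.3-fold higher number (0.11 log units; within the scatter) from compound 2 to compound 4; the limit leaves it open whether they differ What this shows is limited to two cores: the step on the core of compound 2 lies within the scatter and so gives no firm evidence of any effect of the change there, while the other step rests on a limit for compound 1 rather than a number, and agreement in size between the two cores is therefore not shown.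

The compounds shown leave open how other groups on the thiocarbonyl carbon would read out in this series, for example piperidin-1-yl, 4-methylpiperazin-1-yl or an open-chain diethylamino group, on either core. Also open, as far as these compounds go, is whether the change would hold on further cores, and how much of the gap between compound 2 and compound 3 belongs to any single difference between their cores.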